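The source may hold more compounds than are shown below. What is called first, only, known or untested is meant among the compounds shown, and "the series" means these compounds.

Measured so far in a functional assay, read by spectrophotometry, with a stated time of 15 min, tested at 100 ug/mL; a higher number here means a stronger effect of the compound at the concentration tested, a lower number a weaker effect:
compound 1 `Fc1ccc(-c2csc(N/N=C/c3ccc(Cl)cc3Cl)n2)cc1`, compound 1 gives 96%
compound 2 `COC(=O)c1cc(-c2csc(N/N=C/c3ccc(Cl)cc3Cl)n2)ccc1OCc1ccccc1`, compound 2 gives 56.1%

Compound 1 stands highest of the two numbers; the nearest is compound 2, a value lower by an amount beyond the usual scatter. Among the compounds with values here, no step between measured compounds differing in one place is available, so the size of a single substituent change in this assay has not been seen.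

Compound 3 `Clc1ccc(/C=N/Nc2nc(-c3ccccc3)cs2)c(Cl)c1` has not been measured. It differs from compound 1 as follows: hydrogen in place of fluoro on an aromatic carbon. With compound 1 already near the top of the read-out scale, the step from compound 1 to compound 3 is expected to be small, either none beyond the scatter or a modest decrease, a number 9 percentage points lower from compound 1 to compound 3 (within the scatter). For compound 3 the estimate is 87%, with a range from 68% to 99%.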

Compound 3, a percentage reported as inhibition, at one concentration (the size of the read-out at that concentration, not a potency): 95.8%
Estimate against measurement, compound 3: 8.8 percentage points below; measured number inside the range.
By their numbers in this assay, from the lowest: compound 2; then compounds 3 and 1 (each within the scatter of the next).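

In this assay, within the data shown here, the change from 4-fluorophenyl to phenyl gives the first single-place step, a number 0.2 percentage points lower from compound 1 to compound 3 (within the scatter), so fluoro and hydrogen on this aromatic carbon read alike here. Both compounds sit near the top of the read-out scale at the single concentration tested, which leaves little room to see a difference between them. No measurement on hand bears on why the two read alike.

Open, going by these compounds, is whether a larger or charged group at this place, such as an amine, a carboxylic acid or a longer chain, would keep the read-out. Also open, on these data alone, is whether the two compounds would still read alike at a lower concentration.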